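Fluoro to chloro on the open-chain compound 3

The source may report more compounds than this note shows. Statements on the series, on what has been measured and on what is new or still open speak of the compounds shown alone.

Measured so far:
- compound 1, `Cc1ccc(C23CCC(=O)N2CCCO3)c(C)c1`: 150 mg/kg
- compound 2, `O=C1CCC2(c3ccccc3)OCCCN12`: 150 mg/kg
- compound 3, `O=C(CCC(=O)c1ccc(F)cc1)NCCCO`: 500 mg/kg

In a functional assay on the whole organism (Central nervous system) with Mus musculus as the target (on this read-out higher numbers stand for an effect only at larger amounts of compound and lower numbers for an effect already at smaller amounts), compound 3 shows the highest number of the three; compounds 1 and 2 both sit lower, and each of those gaps lies beyond the usual scatter. Compound 4, `O=C(CCC(=O)c1ccc(Cl)cc1)NCCCO`, is not yet measured. It differs from compound 3 by chloro in place of fluoro on an aromatic carbon. Within the data shown here, no measured pair covers a change of this kind, so nothing here shows its direction or size. A step from compound 3 to compound 4 of about a 1.1-fold lower number from compound 3 to compound 4 (0.05 log units; within the scatter) is expected, which would not go beyond the scatter. In this assay compound 4 is estimated at 450 mg/kg, with a range from 200 mg/kg to 1000 mg/kg.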

Compound 4, dose for half-maximal effect: 325 mg/kg
The estimate for compound 4 lay 1.4-fold (0.14 log units) above the measured number, within the range that was stated.
By their numbers in this assay, from the lowest: compounds 1 and 2 (each within the scatter of the next); then compounds 4 and 3 (each within the scatter of the next).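

In this assay, chloro in place of fluoro on an aromatic carbon, para to a large group, gives a 1.5-fold lower number from compound 3 to compound 4 (0.19 log units; within the scatter). This position therefore tolerates the exchange of one halogen for the other without a change that can be separated from the scatter, at least in the open-chain compounds. Nothing measured here accounts for the size of this step.

As far as these compounds go, whether a methoxy group or an amine at this position would give a step beyond the scatter remains open. Also open, from the compounds shown here alone, is whether chloro would behave the same way on the core of compound 2.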